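The source may hold more compounds than are shown below. What is called first, only, known or untested is meant among the compounds shown, and "the series" means these compounds.

Measured compounds:
- compound 1 `COc1cc(OC)c2c(=O)cc(-c3ccc(OCCCN(C)C)cc3)oc2c1`: 59%
- compound 2 `COc1cc(OC)c2c(=O)cc(-c3ccc(OCCN)cc3)oc2c1`: 35%
- compound 3 `COc1cc(OC)c2c(=O)cc(-c3ccc(Br)cc3)oc2c1`: 10%

In a functional assay (Homo sapiens) for antiproliferative activity, read by resazurin assay, with a stated time of 48 h, tested at 10 uM (a higher number here means a stronger effect of the compound at the concentration tested, a lower number a weaker effect), compound 1 gives the highest of the three numbers. Its nearest neighbour is compound 2, reached by the step of a number 24 percentage points lower from compound 1 to compound 2 (beyond the scatter); the furthest is compound 3, reached by the step of a number 49 percentage points lower from compound 1 to compound 3 (beyond the scatter). Between the two smaller compounds the step of a number 25 percentage points lower from compound 2 to compound 3 (beyond the scatter) lies in the same direction.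

Compound 4 `COc1cc(OC)c2c(=O)cc(-c3ccc(NCCN4CCCC4)cc3)oc2c1` has not yet been measured in this assay. It differs from compound 1 in one place: (2-(pyrrolidin-1-yl)ethyl)amino in place of 3-(dimethylamino)propoxy on an aromatic carbon. Both measured steps away from compound 1 bear on this change, since each shortens or removes the chain that carries the amine; the modest loss in the step of a number 24 percentage points lower from compound 1 to compound 2 (beyond the scatter) and the large loss in the step of a number 49 percentage points lower from compound 1 to compound 3 (beyond the scatter) both point downward. Compound 4, however, keeps a chain with a basic nitrogen on its end, so only a small step is expected, a number 7 percentage points lower from compound 1 to compound 4 (within the scatter), roughly within the scatter. The estimate for compound 4 is therefore 52%, with a range from 30% to 72%.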

Compound 4, a percentage reported as inhibition, at one concentration (the size of the read-out at that concentration, not a potency): 51%
For compound 4 the middle estimate is 1 percentage points above the measured one, and the stated range covers the measured number.
By their numbers in this assay, from the lowest: compound 3; then compound 2; then compounds 4 and 1 (each within the scatter of the next).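

In this assay, the oxygen-linked 3-(dimethylamino)propoxy can give way to the nitrogen-linked (2-(pyrrolidin-1-yl)ethyl)amino, which carries a five-membered ring, with a step that stays inside the usual scatter (a number 8 percentage points lower from compound 1 to compound 4 (within the scatter)). The new group also stands clear of both bromo (a number 41 percentage points higher from compound 3 to compound 4 (beyond the scatter)) and 2-aminoethoxy (a number 16 percentage points higher from compound 2 to compound 4 (beyond the scatter)), so this position tolerates more than one chain ending in a fully substituted amine, at least in these four compounds. No measurement here explains these differences.

Compounds 1 and 4 differ at once in the linking atom, the chain and the amine, so the part each plays stays unresolved. A 2-(pyrrolidin-1-yl)ethoxy group would separate the linking atom from the amine, and a morpholine ring would test whether the pyrrolidine can be replaced.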